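The compounds below may be only part of what the source reports. "The series", "measured", "known", "first", "only" and "open" are said of these compounds alone.

Of the compounds shown here, three sharing one core have been measured in an assay on cell membranes for displacement of a labelled ligand from Adrenergic receptor alpha-1 (Rattus norvegicus), tested at 100 nM; a lower number here means a stronger inhibitor, a higher number a weaker inhibitor. Compound 2 `COc1cc2nc(N3CCN(C(=O)/C=C/c4ccccc4)CC3)nc(N)c2cc1OC` gives 0.692 nM, compound 1 `C/C=C/C=C/C(=O)N1CCN(c2nc(N)c3cc(OC)c(OC)cc3n2)CC1` gives 4.37 nM, and compound 3 `COc1cc2nc(N3CCN(C(=O)/C=C/c4ccc(F)cc4)CC3)nc(N)c2cc1OC` gives 22.9 nM, the highest number of the three and thus the weakest inhibitor here. The measured steps that bear on the next change are a 33-fold higher number from compound 2 to compound 3 (1.52 log units; beyond the scatter) and a 5.2-fold higher number from compound 1 to compound 3 (0.72 log units; beyond the scatter). Compound 4 `COc1ccc(/C=C/C(=O)N2CCN(c3nc(N)c4cc(OC)c(OC)cc4n3)CC2)cc1` differs from compound 3 by methoxy in place of fluoro on an aromatic carbon. For the measured compounds named here, no measured pair exchanges fluoro for methoxy, so the direction rests only on the observation that fluoro on this aromatic carbon raised the number; another group there may give a number nearer compound 2 or compound 1. The expected step in this assay is a 4.6-fold lower number from compound 3 to compound 4 (0.66 log units; beyond the scatter), toward a lower number. Compound 4 is therefore estimated at 5 nM, with a range from 0.7 nM to 35 nM.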

Compound 4, half-maximal inhibitory concentration: 3.39 nM
Compound 4: the middle estimate sits 1.5-fold (0.17 log units) above what was measured, within the range that was stated.
By their numbers in this assay, from the lowest: compound 2; then compounds 4 and 1 (each within the scatter of the next); then compound 3.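

In this assay, the aromatic carbon para to a large group responds to which group sits there, not only to whether one does: methoxy gives a much lower number than fluoro (a 6.8-fold lower number from compound 3 to compound 4 (0.83 log units; beyond the scatter)). Methoxy still does not match hydrogen (a 4.9-fold higher number from compound 2 to compound 4 (0.69 log units; beyond the scatter)), so both groups shown on this carbon give a higher number than hydrogen. The 4-methoxyphenyl and prop-1-en-1-yl groups also read alike (a 1.3-fold lower number from compound 1 to compound 4 (0.11 log units; within the scatter)).

No measurement here gives a reason for these steps. On these data alone, how an amine, a chloro group or a longer chain on this carbon would compare remains open.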